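The source may report more compounds than this note shows. Statements on the series, on what has been measured and on what is new or still open speak of the compounds shown alone.

Of the compounds shown here, two of the shared core have been measured. Compound 1 `NC1CCN(c2ccc3cc(NC(=O)CCc4ccc(C(F)(F)F)cc4)ccc3n2)C1` gives 200 nM in a functional assay on HEK293 cells for activation of melanin-concentrating hormone receptor 1 (Rattus norvegicus), read by inositol phosphate accumulation (on this read-out higher numbers stand for an effect only at larger amounts of compound and lower numbers for an effect already at smaller amounts), and compound 2 `O=C(CCc1ccc(C(F)(F)F)cc1)Nc1ccc2nc(N3CCCCC3)ccc2c1` gives 110 nM in the same test; the step of a 1.8-fold lower number from compound 1 to compound 2 (0.26 log units; within the scatter) places compound 2 on the lower of the two numbers, though the gap between them is within the scatter. Compound 3 `CCN(CC)c1ccc2cc(NC(=O)CCc3ccc(C(F)(F)F)cc3)ccc2n1` differs from compound 2 in one place: diethylamino in place of piperidin-1-yl on an aromatic carbon. For the measured compounds named here, the only measured step that bears on this change is the one from compound 1 to compound 2, which swapped one ring-borne amine on the same aromatic carbon for another and stayed within the scatter. With an open chain now replacing a ring, a small shift in this assay is expected, most likely no further than the scatter, with a 1.8-fold higher number from compound 2 to compound 3 (0.26 log units; within the scatter) as the estimated step. Compound 3 is therefore expected to give about 200 nM, within a range from 60 nM to 700 nM.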

Compound 3, half-maximal effective concentration: 830 nM
Compound 3: the middle estimate sits 4.2-fold (0.62 log units) below what was measured; the measured number lies above the stated range.
By their numbers in this assay, from the lowest: compounds 2 and 1 (each within the scatter of the next); then compound 3.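

For the compounds shown here, on the aromatic carbon next to the ring nitrogen, the move from a ring to an open chain is the first change to shift the number in this assay beyond the scatter, with a 7.5-fold higher number from compound 2 to compound 3 (0.88 log units; beyond the scatter) for diethylamino in place of piperidin-1-yl and a 4.2-fold higher number from compound 1 to compound 3 (0.62 log units; beyond the scatter) for diethylamino in place of 3-aminopyrrolidin-1-yl. This position therefore separates these amines: the two ring-borne groups remain within the scatter of each other, while the open-chain group stands apart from both, although diethylamino and piperidin-1-yl have the same donor and acceptor counts. No measurement here accounts for this shift.

The compounds shown leave open whether the higher number goes with the open ring as such or with the two ethyl chains, which a dimethylamino group or a pyrrolidin-1-yl ring on the same carbon could separate. They also leave open whether a morpholin-4-yl ring would stay with the ring-borne amines.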